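The source may report more compounds than this note shows. Statements on the series, on what has been measured and on what is new or still open speak of the compounds shown alone.

Measured so far:

Compound 1, `O=C(CCCCCCc1ccccc1)c1ncc(-c2ccccc2F)o1`, 110 nM
Compound 2, `O=C(CCCCCCc1ccccc1)c1ncc(-c2ccc(F)cc2)o1`, 62 nM
Compound 3, `O=C(CCCCCCc1ccccc1)c1ncc(-c2cncnc2)o1`, 22 nM

These three share one core and differ only in the aromatic group attached to it. In an assay (Rattus norvegicus) for inhibition of Fatty-acid amide hydrolase 1 (Homo sapiens) (a lower number here means a stronger inhibitor, a higher number a weaker inhibitor), compound 3 gives the lowest number of the three: the step of a 5.0-fold lower number from compound 1 to compound 3 (0.70 log units; beyond the scatter) and the step of a 2.8-fold lower number from compound 2 to compound 3 (0.45 log units; beyond the scatter) both go beyond the scatter, whereas the step of a 1.8-fold lower number from compound 1 to compound 2 (0.25 log units; within the scatter) does not.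

Compound 4, `O=C(CCCCCCc1ccccc1)c1ncc(F)o1`, has not yet been measured in this assay. It differs from compound 3 in one place: fluoro in place of pyrimidin-5-yl on an aromatic carbon. Among the compounds with values here, no measured step removes the whole aromatic group; the two steps that reach compound 3 only swap one aromatic group for another and were modest in size. Because the pyrimidin-5-yl group gave the lowest number in a 2.8-fold lower number from compound 2 to compound 3 (0.45 log units; beyond the scatter), replacing it by a single fluorine is expected to raise the number, and the size of that rise is uncertain. The expected step is a 14-fold higher number from compound 3 to compound 4 (1.13 log units; beyond the scatter). Compound 4 is therefore estimated at 300 nM, within a range from 60 nM to 1500 nM.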

Compound 4, inhibition constant: 30 nM
For compound 4 the middle estimate is 10-fold (1.00 log units) above the measured one; the measured number lies below the stated range.
By their numbers in this assay, from the lowest: compounds 3 and 4 (each within the scatter of the next); then compounds 2 and 1 (each within the scatter of the next).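

In this assay, the large aromatic ring at this position proves dispensable: exchanging pyrimidin-5-yl, with its 6 heavy atoms, for a fluoro of 1 heavy atom gives a 1.4-fold higher number from compound 3 to compound 4 (0.13 log units; within the scatter), a step that stays within the scatter. The same fluoro also beats both fluorophenyl groups, with a 2.1-fold lower number from compound 2 to compound 4 (0.32 log units; beyond the scatter) and a 3.7-fold lower number from compound 1 to compound 4 (0.56 log units; beyond the scatter), both modest steps but beyond the scatter. Among these four compounds, then, a low number does not depend on having a ring at this position, and the two fluorophenyl compounds are the ones with the higher numbers.

Nothing in the data given explains why a single fluoro does as well here as pyrimidin-5-yl. Still open, on these data alone, is how a bare hydrogen, a methyl group, an amine or a carboxylic acid would behave on this same ring carbon.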